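Adding a Second Chlorine to a Purine Growth Inhibitor

The source may report more compounds than this note shows. Statements on the series, on what has been measured and on what is new or still open speak of the compounds shown alone.

Measured compounds:
- compound 1 `ClCc1cccc(Cn2cnc3ncnc(Cl)c32)c1`: 1770 nM
- compound 2 `ClCc1ccc(Cn2cnc3c(Cl)nc(Cl)nc32)cc1`: 6610 nM

In a functional assay on TK-10 cells (Homo sapiens) for cytotoxicity, read by sulforhodamine B assay, with a stated time of 48 h (on this read-out higher numbers stand for weaker inhibition of growth and lower numbers for stronger inhibition of growth), compound 1 gives 1770 nM, the lowest of the two numbers measured; compound 2, with 6610 nM in this assay, stands clearly higher, beyond the usual scatter. Compound 2 differs from compound 1 in more than one place, so the two values alone do not isolate the effect of any single change.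

Compound 3 `ClCc1cccc(Cn2cnc3nc(Cl)nc(Cl)c32)c1` has not yet been measured. It differs from compound 1 by a single change: chloro in place of hydrogen on an aromatic carbon of the shared core. Within the data shown here, no measured pair shows this change by itself. On the evidence at hand, the step from compound 1 to compound 3 in this assay is expected to be small, if anything toward a higher number, and may stay within the scatter. The expected step is a 1.4-fold higher number from compound 1 to compound 3 (0.15 log units; within the scatter). Compound 3 is therefore estimated at 2500 nM, with a range from 900 nM to 7000 nM.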

Compound 3, concentration for 50% growth inhibition: 16600 nM
The estimate for compound 3 lay 6.6-fold (0.82 log units) below the measured number; the whole stated range lies below it.
By their numbers in this assay, from the lowest: compound 1; then compound 2; then compound 3.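

In this assay, putting chloro in place of hydrogen on the aromatic carbon between two ring nitrogen atoms gives a 9.4-fold higher number from compound 1 to compound 3 (0.97 log units; beyond the scatter), so growth inhibition clearly weakens. Among these compounds, this is the first reading of this change on its own, and it shows that this position of the shared core is sensitive to what sits there, even when the new group adds only 1 heavy atom. No available measurement explains why the step is this large.

On these data alone, it remains open whether an amine or a methoxy group on the same carbon would weaken growth inhibition as chloro does, or would be tolerated better. Since this is a single pair of compounds, it is also unknown whether the same change would give a similar step with a different group on the benzyl ring of compound 1.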